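Moving the nitro group on a pyrazoline-bound phenyl ring

The source may report more compounds than this note shows. Statements on the series, on what has been measured and on what is new or still open speak of the compounds shown alone.

Of the compounds shown here, three built on a shared core have been tested in a functional assay on the whole organism (plasma, strain albino) for inhibition, with Rattus norvegicus as the target, with stated times of 1 h and 4 h, at a dose of 50 mg/kg by the oral route; a lower number here means a weaker effect, a higher number a stronger effect of the compound at the dose given. Compound 1, `COc1ccc(Cl)cc1C(=O)Nc1ccc(C2=NN(C)C(c3ccc([N+](=O)[O-])cc3)C2)cc1`, gives 83.2%. Compound 2, `COc1ccc(C2CC(c3ccc(NC(=O)c4cc(Cl)ccc4OC)cc3)=NN2c2ccccc2)cc1`, gives 90.2%. Among the measured compounds shown here, compound 3, `COc1ccc(Cl)cc1C(=O)Nc1ccc(C2=NN(c3ccccc3)C(c3ccccc3[N+](=O)[O-])C2)cc1`, gives 84.4%, and this number lies within the usual scatter of both neighbours: compound 1 is close to it, and the only measured single change, a number 5.8 percentage points lower from compound 2 to compound 3 (within the scatter), also stays within the scatter. So compound 3 cannot be told apart from the other two on these numbers.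

The next compound, compound 4, `COc1ccc(Cl)cc1C(=O)Nc1ccc(C2=NN(c3ccccc3)C(c3ccc([N+](=O)[O-])cc3)C2)cc1`, keeps every atom of compound 3 and only rearranges one group: 4-nitrophenyl in place of 2-nitrophenyl on a saturated ring carbon. For the measured compounds named here, the measured step that bears on this is the one from compound 2 to compound 3, where a different group was swapped on the same saturated ring carbon and the read-out hardly moved. Compound 1 carries a 4-nitrophenyl at that carbon as well, though with a different group on the ring nitrogen, and its value sits close to compound 3. Nothing here points to a change beyond the scatter, so for compound 4 the expected step is a number 0.6 percentage points higher from compound 3 to compound 4 (within the scatter). Compound 4 is therefore estimated at 85%, within a range of 76% to 93%.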

Compound 4, a percentage reported as inhibition, in the whole organism at one dose (the size of the read-out at that dose, not a potency): 85.3%
For compound 4 the middle estimate is 0.3 percentage points below the measured one; measured number inside the range.
By their numbers in this assay, from the lowest: compounds 1, 3, 4 and 2 (each within the scatter of the next).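

Moving the nitro group from the 2-nitrophenyl to the 4-nitrophenyl arrangement on the saturated ring carbon gives a number 0.9 percentage points higher from compound 3 to compound 4 (within the scatter) in this assay, so for this pair, the first to hold every atom fixed, the place of the nitro group on that phenyl ring leaves no readable mark on the result. Compound 4 also links two other changes that can now be read on their own: nitro in place of methoxy on an aromatic carbon gives a number 4.9 percentage points lower from compound 2 to compound 4 (within the scatter), and phenyl in place of methyl on the ring nitrogen gives a number 2.1 percentage points higher from compound 1 to compound 4 (within the scatter), so neither of these single changes separates its pair either. No measurement at hand offers a reason for these small steps.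

Every group shown on the saturated ring carbon is a substituted phenyl ring, so it stays open whether something of another kind there, such as a carboxylic acid or an amine on a longer chain, would give a step beyond the scatter. A read-out at one oral dose is also not a potency, so compounds that cannot be told apart at this dose might still differ at a smaller one.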